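Swapping the benzyl-type arm for isobutyl: expected tolerance

This account rests on a few compounds, and the source may have more. Where it says the series, first, only, none or still open, it means among the compounds named here.

Compound 1, `Cc1ccc(Cn2ccc3nc(-c4ccccc4)nc-3c2)cc1`: > 100000 nM in an ADME assay on MDBK cells (Bos taurus) for cytotoxicity; a higher number here means that more compound is tolerated, a lower number that less compound is tolerated; this is a limit of the assay.
Compound 2, `COc1ccc(Cn2ccc3nc(-c4ccccc4)nc-3c2)cc1`: > 100000 nM in this assay; this too is a limit of the assay.
Compound 3, `Brc1cccc(Cn2ccc3nc(-c4ccccc4)nc-3c2)c1`: 85000 nM in this assay.

Compound 3 is the only one of the three with an actual number; compound 1 and compound 2 both sit at the limit of > 100000 nM in this assay, at which 2 of the 3 values shown sit. Compound 4, `CC(C)CCn1ccc2nc(-c3ccccc3)nc-2c1`, differs from compound 3 in one place: isobutyl in place of 3-bromophenyl on a saturated chain carbon bound to an aromatic nitrogen. For the measured compounds named here, the steps that bear on this change are an at least 1.1-fold lower number from compound 1 to compound 3 (0.07 log units; that floor lies within the scatter) and an at least 1.1-fold lower number from compound 2 to compound 3 (0.07 log units; that floor lies within the scatter), both within the scatter. A change at the same place is therefore expected to give no step beyond the scatter, so compound 4 is estimated at 100000 nM (range 40000 nM to 300000 nM), a step of a 1.2-fold higher number from compound 3 to compound 4 (0.07 log units; within the scatter) that is expected to stay inside the scatter.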

Compound 4, half-maximal cytotoxic concentration: > 100000 nM
Compound 4: no number, only a limit; the forecaster's own chance of this, stated with the estimate: 55%; the middle value lies on the limit itself.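

Compound 4 shows that this position, on a saturated chain carbon bound to an aromatic nitrogen, can carry isobutyl with no aromatic ring and still reach a limit of the assay rather than a number. For the compounds shown here, the only readable step is an at least 1.1-fold higher number from compound 3 to compound 4 (0.07 log units; that floor lies within the scatter), while the steps from compound 1 and compound 2 cannot be read. The series now mostly rests on one ceiling: the limit of > 100000 nM in this assay, at which 3 of the 4 values shown sit.

From the compounds shown here alone, how much more compound 1, compound 2 and compound 4 would tolerate stays open. So does the effect of an amine or a carboxylic acid at this position.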